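Trifluoromethyl to 4-(trifluoromethyl)phenyl: cytotoxicity notes

A few compounds are considered here, and "the series" means these few. Any claim that something is new, unique, unknown or untested is made for them only; others in the source may bear on it.

Compound 1 (`CC1(COc2ccc(C(F)(F)F)cn2)Cn2cc([N+](=O)[O-])nc2O1`) is the starting point in an ADME assay on MRC5 cells (Homo sapiens) for cytotoxicity, read by fluorescence, with a stated time of 72 h; on this read-out higher numbers stand for weaker inhibition and lower numbers for stronger inhibition. There, compound 1 gives > 64000 nM, which is a limit of the assay and not a number. Compound 2 (`CC1(COc2ccc(-c3ccc(C(F)(F)F)cc3)cc2)Cn2cc([N+](=O)[O-])nc2O1`) gives > 64000 nM in this assay, which is also a limit. The record so far is therefore (the limit of > 64000 nM in this assay, at which 2 of the 2 values shown sit). Among the compounds with values here, no numerical value is available for either compound, and no step between them can be read.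

Compound 3 (`CC1(COc2ccc(-c3ccc(C(F)(F)F)cc3)cn2)Cn2cc([N+](=O)[O-])nc2O1`) carries 4-(trifluoromethyl)phenyl in place of trifluoromethyl on an aromatic carbon of a six-membered aromatic ring with 1 nitrogen, two atoms from the ring nitrogen: 4-(trifluoromethyl)phenyl in place of trifluoromethyl on an aromatic carbon.

No step beyond the scatter is expected in this assay, in either direction, since compound 2 gives > 64000 nM, a limit, while also bearing a 4-(trifluoromethyl)phenyl group. The estimated step of a number no higher from compound 1 to compound 3 (the limit leaves the size open) is expected to stay within the scatter. For compound 3 the estimate is 64000 nM, with an expected range of 30000 nM to 100000 nM, and the result is most likely to be reported as a limit again.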

Compound 3, half-maximal inhibitory concentration: > 64000 nM
Compound 3: a limit, no number (the forecaster's own chance of this, stated with the estimate: 85%); the middle value lies on the limit itself.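

In this assay, within the data shown here, compound 3 gives a limit and not a number, as compound 1 does, so no step between compound 1 and compound 3 can be read: the limit of > 64000 nM in this assay, at which 3 of the 3 values shown sit. The compounds shown leave open how far each lies from that limit, and whether the change from trifluoromethyl to 4-(trifluoromethyl)phenyl has any effect on cytotoxicity.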